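The compounds below may be only part of what the source reports. "The series", "measured", "known", "first", "only" and "open" are said of these compounds alone.

Measured so far in an ADME assay on microsomes from liver (Homo sapiens) for metabolic stability, read by LC-MS, using NADPH, with stated times of 5 min and 30 min, tested at 1 uM; on this read-out higher numbers stand for fast clearance and lower numbers for slow clearance:

Compound 1 `Cc1nc(CO)ccc1-c1cnc(NCc2c(F)ccc3c2CCO3)c2cn[nH]c(=O)c12` gives 11 mL.min-1.g-1 in this assay.
Compound 2 `Cc1ncc(-c2cnc(NCc3c(F)ccc4c3CCO4)c3cn[nH]c(=O)c23)n1C` gives 10 mL.min-1.g-1 in this assay.

Among the measured compounds shown here, compound 2 stands with compound 1 within the scatter of each other; the only step among the measured pair, a 1.1-fold lower number from compound 1 to compound 2 (0.04 log units; within the scatter), is a change at the same aromatic carbon that compound 3 alters again, and it moved the read-out by no more than repeated measurements would.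

Compound 3 `Cc1nn(C)cc1-c1cnc(NCc2c(F)ccc3c2CCO3)c2cn[nH]c(=O)c12` is not yet measured. It differs from compound 2 as follows: 1,3-dimethyl-1H-pyrazol-4-yl in place of 1,2-dimethyl-1H-imidazol-5-yl on an aromatic carbon. For the measured compounds named here, the one step that bears on this change is the one from compound 1 to compound 2, in which one five-membered or six-membered aryl group replaced another at this position with no movement beyond the scatter. On that basis no step beyond the scatter is expected here either, in either direction: the step from compound 2 to compound 3 is estimated as no change at the digits printed from compound 2 to compound 3 (within the scatter).

For compound 3 the expected value in this assay is 10 mL.min-1.g-1, with a range from 5 mL.min-1.g-1 to 20 mL.min-1.g-1.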

Compound 3, intrinsic clearance in microsomes: 27 mL.min-1.g-1
Compound 3: middle estimate off by 2.7-fold (0.43 log units), on the low side; measured number outside the range, above it.
By their numbers in this assay, from the lowest: compounds 2 and 1 (each within the scatter of the next); then compound 3.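

In this assay this aromatic carbon proves sensitive to how a five-membered aryl group is built: 1,3-dimethyl-1H-pyrazol-4-yl in place of 1,2-dimethyl-1H-imidazol-5-yl gives a 2.7-fold higher number from compound 2 to compound 3 (0.43 log units; beyond the scatter), although the two groups match in heavy atoms, ring type, hydrogen-bond donors and acceptors, and net charge, so these counts do not separate them. With 6-(hydroxymethyl)-2-methylpyridin-3-yl as the group leaving, the change gives a 2.5-fold higher number from compound 1 to compound 3 (0.39 log units; beyond the scatter), which is also beyond the scatter, so compound 3 stands apart from both earlier compounds, and the agreement of compound 1 and compound 2 does not show a general tolerance for aryl changes here. No measurement is available that explains this difference between isomeric groups.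

In this change the ring nitrogens and the methyl groups shift together, and the compounds shown cannot separate their contributions. Also open, going by these compounds, is how the read-out would respond to an amine or a carboxylic acid on the 1,3-dimethyl-1H-pyrazol-4-yl group, or to a cyclopropyl group in place of one of its methyl groups.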